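A Methoxy Swap on a Saturated Ring Carbon

This account rests on a few compounds, and the source may have more. Where it says the series, first, only, none or still open, it means among the compounds named here.

Among the measured compounds shown here, in a functional assay on MDA-MB-231 cells (Homo sapiens) for inhibition, read by MTT assay, with a stated time of 72 h (on this read-out higher numbers stand for weaker inhibition and lower numbers for stronger inhibition), compound 2 `CC1=NN(c2ccccc2)C(=O)[C@]12C(=O)C=CC[C@H]2c1cccc(C)c1` gives 10300 nM and so holds the lower of the two numbers measured so far. For the measured compounds named here, compound 1 `CC1=NN(c2ccccc2)C(=O)[C@]12C(=O)C=CC[C@H]2c1ccccc1[N+](=O)[O-]` gives 32400 nM as the only other number on hand. Compound 3 `COc1ccccc1[C@@H]1CC=CC(=O)[C@]12C(=O)N(c1ccccc1)N=C2C` is still unmeasured. Compared with compound 2, it carries 2-methoxyphenyl in place of 3-methylphenyl on a saturated ring carbon, with the shared core unchanged. Going by the values given here, the one measured step that bears on this change is a 3.1-fold lower number from compound 1 to compound 2 (0.50 log units; beyond the scatter) at that same ring carbon. Among the compounds with values here, no measured compound carries 2-methoxyphenyl, so that step only sets a scale for swaps at this carbon. Within the data shown here, a small rise in this assay is expected rather than a further fall, no larger than that step and perhaps within the scatter. The estimated change is a 1.6-fold higher number from compound 2 to compound 3 (0.19 log units; within the scatter) in this direction. For compound 3 the estimate is 16000 nM with an expected range from 6500 nM to 40000 nM as the likely span of repeat measurements.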

Compound 3, half-maximal inhibitory concentration: 5140 nM
Beside the measured number, compound 3's estimate is 3.1-fold (0.49 log units) above it; the whole stated range lies above it.
By their numbers in this assay, from the lowest: compounds 3 and 2 (each within the scatter of the next); then compound 1.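

In this assay, the swap at the saturated ring carbon gives a 2.0-fold lower number from compound 2 to compound 3 (0.30 log units; within the scatter), so this assay does not separate 2-methoxyphenyl from 3-methylphenyl, and the added oxygen and hydrogen-bond acceptor of the entering group bring no change that can be read beyond the scatter. The clearer contrast is on the aromatic carbon, where methoxy in place of nitro gives a 6.3-fold lower number from compound 1 to compound 3 (0.80 log units; beyond the scatter), which sets compound 1, the 2-nitrophenyl member, apart from both compound 2 and compound 3, with each of its steps to them printed as beyond the scatter. Nothing on hand explains why the nitro compound stands apart in this way.

Among the compounds shown here, with only three compounds, it remains open whether compound 1 stands apart through the nitro group itself or whether other groups on that aromatic carbon would behave the same way. A plain phenyl, or an amine or a hydroxyl on that same aromatic carbon, would show whether the numbers of compound 2 and compound 3 mark a general level for this position or hold only for these two groups.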